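Solubility notes: the benzyl imide series, compound 2 to compound 4

The source may report more compounds than this note shows. Statements on the series, on what has been measured and on what is new or still open speak of the compounds shown alone.

Compound 1 `Cc1nc(C(N)=O)c(N)c2c1C(=O)N(Cc1ccccc1)C2=O`, compound 2 `Cc1noc(-c2nc(C)c3c(c2N)C(=O)N(Cc2ccccc2)C3=O)n1` and compound 3 `COc1ccccc1CN1C(=O)c2c(C)nc(-c3nc(C)no3)c(N)c2C1=O` share one imide core. In a physicochemical assay for solubility, using the shake flask method, in simulated intestinal fluid, measured as kinetic solubility, with a stated time of 2 h, at 25 degrees C, at pH 6.5 (a lower number here means a less soluble compound, a higher number a more soluble compound), compound 1 gives < 5000 nM, a limit of the assay. In this assay compound 2 gives < 5000 nM, also a limit. In this assay compound 3 gives < 5000 nM, a limit as well. All three sit at the limit of < 5000 nM in this assay, at which 3 of the 3 values shown sit, so a step that the two limits leave unreadable from compound 1 to compound 2 and a step that the two limits leave unreadable from compound 2 to compound 3 are unreadable. Compound 4 `Cc1noc(-c2nc(C)c3c(c2N)C(=O)N(Cc2ccc(SC(F)(F)F)cc2)C3=O)n1` differs from compound 2 by (trifluoromethyl)sulfanyl in place of hydrogen on an aromatic carbon. Neither measured step bears readably on this change, so the expectation for compound 4 is a value at or under the same limit. Compound 4 is expected to give 1500 nM, within 200 nM to 5000 nM. The expected step is a step that the limit leaves unreadable from compound 2 to compound 4.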

Compound 4, solubility: < 5000 nM
Compound 4 gave a limit, no number; the forecaster's own chance of this, stated with the estimate: 80%; the middle value does not contradict the limit.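

The step from compound 2 to compound 4 cannot be read, since both compounds give only a limit: the limit of < 5000 nM in this assay, at which 4 of the 4 values shown sit.

The compounds shown leave open how soluble any of them actually is, and what (trifluoromethyl)sulfanyl in place of hydrogen does to solubility.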